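The compounds below may be only part of what the source reports. "The series", "measured", "known", "first", "only" and "open" are said of these compounds alone.

Measured in an ADME assay on HepG2 cells (Homo sapiens) for cytotoxicity; on this read-out higher numbers stand for lower toxicity in this test and lower numbers for higher toxicity in this test:

- Compound 1 `CSc1cccc(N2C(=O)c3ccc(-c4ccco4)n3CC2(C)C(=O)NC2CCCC2)c1`: > 50000 nM (a limit of the assay, not a number)
- Compound 2 `CSc1cccc(N(CC(=O)NC2CCCC2)C(=O)c2cc3ccc(C(F)(F)F)cc3n2C)c1`: 6300 nM
- Compound 3 `CSc1cccc(N2C(=O)CN(c3cccc(C(F)(F)F)c3)CC2C(=O)NC2CCCC2)c1`: 20000 nM

Only two of these three results are true numbers. In this assay, compound 3 has the higher of them at 20000 nM, and compound 2 sits at 6300 nM, a gap beyond the usual scatter of the test.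

Compound 4 `CSc1cccc(N2C(=O)CN(c3cncc(C(F)(F)F)c3)CC2C(=O)NC2CCCC2)c1` is compound 3 with one change: 5-(trifluoromethyl)pyridin-3-yl in place of 3-(trifluoromethyl)phenyl on an amine nitrogen in a ring. The rest of the molecule stays the same. For the measured compounds named here, no measured pair of compounds shows what this kind of swap does, so any forecast is loose. A small move towards a higher number is expected, and it may well stay within the scatter. The expected change is a 1.4-fold higher number from compound 3 to compound 4 (0.15 log units; within the scatter). For compound 4 the estimated value in this assay is 28000 nM, with an expected range from 12000 nM to 50000 nM.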

Compound 4, half-maximal cytotoxic concentration: > 50000 nM
Compound 4 ended at the assay's limit; the forecaster's own chance of this, stated with the estimate: 30%; middle value at least 1.7-fold (0.25 log units) from the limit.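

In this assay, for the compounds shown here, putting 5-(trifluoromethyl)pyridin-3-yl in place of 3-(trifluoromethyl)phenyl gives an at least 2.5-fold higher number from compound 3 to compound 4 (0.39 log units; beyond the scatter), the first comparison here of compounds that differ in one place, and it shows that this group on the ring amine nitrogen bears on the read-out. The entering ring differs by a single ring nitrogen, which counts as a hydrogen-bond acceptor, yet the result moves towards lower toxicity in this test by more than the usual scatter. The true size of the step stays unknown, because the value of compound 4 is a limit and not a number: the limit of > 50000 nM in this assay, at which 2 of the 4 values shown sit.

On these data alone, whether a nitrile in place of the trifluoromethyl, or a pyrimidine in place of the pyridine, would give the same result remains open. So does whether the ring nitrogen itself accounts for the step, since this single pair cannot separate its role from any other explanation.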